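A few compounds are considered here, and "the series" means these few. Any claim that something is new, unique, unknown or untested is made for them only; others in the source may bear on it.

Compound 1 `COc1ccc(-c2cnc(NC(=O)c3cccnc3)n2C)cc1` is one of three compounds tested in a toxicity assay on THP-1 cells (Homo sapiens) for inhibition; on this read-out higher numbers stand for lower toxicity in this test and lower numbers for higher toxicity in this test. For compound 1 this assay reports only a limit, > 100000 nM, and not a number (the limit of > 100000 nM in this assay, at which 1 of the 3 values shown sits). Compound 2 `COc1ccccc1-c1cnc(NC(=O)c2ncc[nH]2)n1C` likewise gives only a limit in this assay, > 50000 nM (the limit of > 50000 nM in this assay, at which 1 of the 3 values shown sits). Compound 3 `COc1ccc(-c2cnc(NC(=O)c3ccc(F)cc3)n2-c2ccccc2)cc1` gives a number in this assay, 8800 nM. Compound 1 thus stands at a limit, and one of the two other values shown is also a limit. Compound 4 `COc1ccc(-c2cnc(NC(=O)c3ccccc3C#N)n2C)cc1` has not yet been tested; it carries 2-cyanophenyl in place of pyridin-3-yl on a carbonyl carbon. Within the data shown here, no step between measured compounds covers this change; the expected move in this assay is an at least 1.2-fold lower number from compound 1 to compound 4 (0.09 log units; that floor lies within the scatter), none beyond the scatter. Compound 4 is expected to give 80000 nM, within 20000 nM to 200000 nM.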

Compound 4, half-maximal cytotoxic concentration: > 100000 nM
Compound 4: no number, only a limit; the forecaster's own chance of this, stated with the estimate: 60%; at least 1.2-fold (0.09 log units) between middle value and limit.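

Compound 1 and compound 4 both give only a limit, not a number, in this assay, so no step between them can be read: the limit of > 100000 nM in this assay, at which 2 of the 4 values shown sit.

The compounds shown leave open whether 2-cyanophenyl in place of pyridin-3-yl changes toxicity in this test at all.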